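Cytotoxicity on Huh-7 cells: from a pyrazole to a cyanophenyl

A few compounds are considered here, and "the series" means these few. Any claim that something is new, unique, unknown or untested is made for them only; others in the source may bear on it.

Of the compounds shown here, three have been measured in an ADME assay on Huh-7 cells (Homo sapiens) for cytotoxicity, read by MTT assay, with a stated time of 48 h; on this read-out lower numbers stand for higher toxicity in this test and higher numbers for lower toxicity in this test. Compound 1 `CN(C)CCCCN(C(=O)O)c1ccc(N2N=C(c3ccc(F)cc3)C3C=CC=CC3C2=O)cc1` gives 21800 nM, compound 2 `CN(C)CCCCC(=O)Nc1ccc(CN2N=C(c3ccc(F)cc3)C3C=CC=CC3C2=O)cc1` gives 77700 nM, and compound 3 `CN(C)CCCCOC(=O)Nc1ccc(Cn2nc(-c3cnn(C)c3)c3ccccc3c2=O)cc1` gives 55900 nM. Compound 3 thus stands second highest of the three numbers; its value and that of compound 2 lie within the usual scatter of each other, whereas compound 1 gives a clearly lower number. Compound 4 `CN(C)CCCCOC(=O)Nc1ccc(Cn2nc(-c3cccc(C#N)c3)c3ccccc3c2=O)cc1` differs from compound 3 by 3-cyanophenyl in place of 1-methyl-1H-pyrazol-4-yl on an aromatic carbon. Going by the values given here, no pair of the measured compounds differs in one place only, so no measured step guides this change. A modest move toward a lower number, or none beyond the scatter, is expected for compound 4, with a 1.3-fold lower number from compound 3 to compound 4 (0.12 log units; within the scatter) as the expected step. The estimate for compound 4 in this assay is 42000 nM, within a range from 15000 nM to 110000 nM.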

Compound 4, half-maximal cytotoxic concentration: 17200 nM
Compound 4: middle estimate off by 2.4-fold (0.39 log units), on the high side, and the stated range covers the measured number.
By their numbers in this assay, from the lowest: compounds 4 and 1 (each within the scatter of the next); then compounds 3 and 2 (each within the scatter of the next).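

In this assay 3-cyanophenyl in place of 1-methyl-1H-pyrazol-4-yl on the aromatic carbon next to the ring nitrogen gives a 3.3-fold lower number from compound 3 to compound 4 (0.51 log units; beyond the scatter) and so shows that a change at this position alone can move the number beyond the scatter. The earlier compounds shown here could not show this, since none of them differed in one place only. No evidence is available on what lies behind this step. This single step does not separate the nitrile from the six-membered ring that carries it. Going by these compounds, an unsubstituted phenyl, an amine or a carboxylic acid at this position remains open.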